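From 3-cyanophenyl to 1H-indol-6-yl on a shared core

A few compounds are considered here, and "the series" means these few. Any claim that something is new, unique, unknown or untested is made for them only; others in the source may bear on it.

Compound 3 `COc1cc(-c2ccnc3cc(-c4cccc(C#N)c4)nn23)cc(OC)c1OC` stands at the weak end of the three compounds measured in a functional assay on A549 cells (Homo sapiens) for inhibition, read by CCK-8 assay, with a stated time of 48 h; a lower number here means a stronger inhibitor, a higher number a weaker inhibitor. Compound 3 gives > 10000 nM, which is a limit of the assay and not a number. In this assay compound 1 `COc1cc(-c2ccnc3cc(-c4ccc(F)cc4)nn23)cc(OC)c1OC`, with a 4-fluorophenyl group, gives 3800 nM, and compound 2 `COc1cc(-c2ccnc3cc(-c4ccc(C)c(C)c4)nn23)cc(OC)c1OC`, with a 3,4-dimethylphenyl group, gives 272 nM.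

Compound 4 `COc1cc(-c2ccnc3cc(-c4ccc5cc[nH]c5c4)nn23)cc(OC)c1OC` keeps the shared core and changes a single group: 1H-indol-6-yl in place of 3-cyanophenyl on an aromatic carbon. The exchange takes place on an aromatic carbon of a five-membered aromatic ring with 2 nitrogen, the same place where the measured compounds differ.

All three measured steps therefore bear on it. The change to 3,4-dimethylphenyl gave a 14-fold lower number from compound 1 to compound 2 (1.15 log units; beyond the scatter), and the change to 3-cyanophenyl gave an at least 2.6-fold higher number from compound 1 to compound 3 (0.42 log units; beyond the scatter). The widest, an at least 36-fold higher number from compound 2 to compound 3 (1.56 log units; beyond the scatter), shows how far this one group can move the number. Within the data shown here, no measured compound carries an indole. The 1H-indol-6-yl group has no nitrile, so compound 4 is expected to sit nearer to compound 2 at 272 nM than to compound 3. A large fall is therefore expected, an at least 40-fold lower number from compound 3 to compound 4 (1.60 log units; beyond the scatter). The estimate in this assay for compound 4 is 250 nM, with an expected range from 50 nM to 2500 nM.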

Compound 4, half-maximal inhibitory concentration: 170 nM
Beside the measured number, compound 4's estimate is 1.5-fold (0.17 log units) above it; the measured number falls inside the stated range.
By their numbers in this assay, from the lowest: compounds 4 and 2 (each within the scatter of the next); then compound 1. At a limit, above all of these: compound 3.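

Compound 3 stands at a limit of the assay and not at a number: the limit of > 10000 nM in this assay, at which 1 of the 4 values shown sits.

Even so, in this assay the 1H-indol-6-yl group in place of 3-cyanophenyl gives an at least 58-fold lower number from compound 3 to compound 4 (1.76 log units; beyond the scatter), and in place of 4-fluorophenyl it gives a 22-fold lower number from compound 1 to compound 4 (1.35 log units; beyond the scatter), which shows that this aromatic carbon of the shared core accepts a group with a five-membered aromatic ring fused to the six-membered one. Against 3,4-dimethylphenyl the same kind of exchange gives a 1.6-fold lower number from compound 2 to compound 4 (0.20 log units; within the scatter), which lies within the scatter, so among these compounds a low number at this position is not tied to the two methyl groups of compound 2.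

The compounds shown leave open whether the hydrogen on the indole nitrogen counts for the number, a question that a 1-methylindol-6-yl or a benzofuran-6-yl group would address. They also leave open whether the point of attachment on the indole matters, as a 1H-indol-5-yl group at the same aromatic carbon would show.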